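This account rests on a few compounds, and the source may have more. Where it says the series, first, only, none or still open, it means among the compounds named here.

Measured so far in an assay on isolated protein for inhibition of Indoleamine 2,3-dioxygenase 1 (Homo sapiens), read by fluorescence, with a stated time of 60 min; on this read-out lower numbers stand for stronger inhibition and higher numbers for weaker inhibition:
compound 1, `O=S(=O)(CCNc1nonc1/C(=N/O)Nc1ccc(F)c(Br)c1)N1CCC1`: 191 nM
compound 2, `O=S(=O)(CCNc1nonc1/C(=N/O)Nc1ccc(F)c(Br)c1)NCC1CC1`: 312 nM

Compound 2 stands at the higher of the two numbers, though the step of a 1.6-fold higher number from compound 1 to compound 2 (0.21 log units; within the scatter) is within the scatter. Compound 3, `O=S(=O)(CCNc1nonc1/C(=N/O)Nc1ccc(F)c(Br)c1)NO`, carries hydroxy in place of cyclopropylmethyl on a sulfonamide nitrogen. Going by the values given here, the one step that bears on this place, a 1.6-fold higher number from compound 1 to compound 2 (0.21 log units; within the scatter), was itself within the scatter. In this assay a change of similar size is therefore expected, if anything towards a higher number, so the estimated step of a 1.3-fold higher number from compound 2 to compound 3 (0.11 log units; within the scatter) stays small. Compound 3 is expected to give about 400 nM, with a range of 150 nM to 1100 nM.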

Compound 3, half-maximal inhibitory concentration: 126 nM
Compound 3: middle estimate off by 3.2-fold (0.50 log units), on the high side; measured number outside the range, below it.
By their numbers in this assay, from the lowest: compounds 3, 1 and 2 (each within the scatter of the next, the first and the last beyond it).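

In this assay, going by these compounds alone, hydroxy in place of cyclopropylmethyl on the sulfonamide nitrogen gives a 2.5-fold lower number from compound 2 to compound 3 (0.39 log units; beyond the scatter) and is the first step at this place to lie beyond the scatter, so the substituent here can move the read-out. Hydroxyamino in place of azetidin-1-yl on the sulfonyl sulfur gives a 1.5-fold lower number from compound 1 to compound 3 (0.18 log units; within the scatter) and stays within the scatter, so the hydroxy compound separates from only one of the two earlier compounds. Nothing available explains this difference.

Going by these compounds, it remains open whether the step comes from gaining the hydroxy group or losing cyclopropylmethyl. A methoxy group, a methyl group or an unsubstituted sulfonamide nitrogen would help separate these two readings.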